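This account rests on a few compounds, and the source may have more. Where it says the series, first, only, none or still open, it means among the compounds named here.

Working notes on the series.

Compound 1 `O=C(CCc1ccc(-c2ccccc2)cc1)c1ncc(-c2ccncc2)o1` is the reference point. Within the data shown here, in an assay for inhibition of Fatty-acid amide hydrolase 1 (Rattus norvegicus) (a higher number here means a weaker inhibitor, a lower number a stronger inhibitor), compound 1 gives 2.3 nM, the second highest of the three numbers so far. Among the measured compounds shown here, compound 3 `COC(=O)c1cc(-c2cnc(C(=O)CCc3ccc(-c4ccccc4)cc3)o2)ccn1` gives 1.5 nM in this assay, and the step of a 1.5-fold lower number from compound 1 to compound 3 (0.19 log units; within the scatter) is the only single-point change measured. Compound 2 `COC(=O)c1cccc(-c2cnc(C(O)CCc3ccc(-c4ccccc4)cc3)o2)n1` gives 9000 nM in this assay; compound 2 differs from compound 1 in more than one place, so its value shows only that a large gap exists in the series, not which change carries it.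

Compound 4 `NC(=O)c1cccc(-c2cnc(C(=O)CCc3ccc(-c4ccccc4)cc3)o2)n1` carries the change (6-carbamoylpyridin-2-yl in place of pyridin-4-yl on an aromatic carbon). For the measured compounds named here, no measured step bears directly on this change. The step from compound 1 to compound 3 shows that adding a methoxycarbonyl group to the outer ring leaves the number within the scatter, which suggests the core tolerates a substituent on that ring, but the ring attachment itself is not varied anywhere in the measured set. The estimate for compound 4 is therefore a step of a 1.3-fold higher number from compound 1 to compound 4 (0.12 log units; within the scatter), expected to stay near compound 1 with a wide range. Compound 4 is expected to give 3 nM in this assay, between 0.7 nM and 15 nM.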

Compound 4, inhibition constant: 1.2 nM
For compound 4 the middle estimate is 2.5-fold (0.40 log units) above the measured one; measured number inside the range.
By their numbers in this assay, from the lowest: compounds 4, 3 and 1 (each within the scatter of the next); then compound 2.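

Among these compounds, at this position, next to the ring oxygen, the ring attachment and the substituent vary together for the first time, and the step of a 1.9-fold lower number from compound 1 to compound 4 (0.28 log units; within the scatter) in this assay shows that 6-carbamoylpyridin-2-yl is accepted as readily as pyridin-4-yl. The step of a 1.3-fold lower number from compound 3 to compound 4 (0.10 log units; within the scatter) adds that 6-carbamoylpyridin-2-yl and 2-(methoxycarbonyl)pyridin-4-yl cannot be told apart here, so the separate contributions of the carbamoyl group and the changed attachment remain unresolved. No available evidence accounts for this result.

The compounds shown leave open whether an unsubstituted pyridin-2-yl group would stay in the same range, which would isolate the attachment from the carbamoyl group. They also leave open whether a carboxylic acid or an aminomethyl group in place of the carbamoyl group would hold the number.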